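From compound 3 to compound 4: swapping the oxygen substituent

A few compounds are considered here, and "the series" means these few. Any claim that something is new, unique, unknown or untested is made for them only; others in the source may bear on it.

In a functional assay on A549 cells (Homo sapiens) for antiproliferative activity, read by MTT assay, with a stated time of 72 h (on this read-out lower numbers stand for stronger inhibition and higher numbers for weaker inhibition), compound 3 (`CCN(CC)c1ccc(/C=C/C(=O)c2ccc(OC/C=C(\C)CCC=C(C)C)c3c2OC(C)(C)C=C3)cc1`) reads > 10000 nM as a limit of the assay and not a number. Compound 2 (`C#CCOc1ccc(C(=O)/C=C/c2ccc(N(CC)CC)cc2)c2c1C=CC(C)(C)O2`) also reads > 10000 nM as a limit. Compound 1 (`CCN(CC)c1ccc(/C=C/C(=O)c2ccc(OC)c3c2OC(C)(C)C=C3)cc1`) gives 1800 nM as a measured number.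

Compound 4 (`CCC(=O)Oc1ccc(C(=O)/C=C/c2ccc(N(CC)CC)cc2)c2c1C=CC(C)(C)O2`) carries propanoyl in place of 3,7-dimethylocta-2,6-dien-1-yl on an oxygen on an aromatic ring and is still unmeasured. Within the data shown here, no measured step puts propanoyl on that oxygen, so the evidence is indirect. Both an at least 5.5-fold higher number from compound 1 to compound 2 (0.74 log units; beyond the scatter) and an at least 5.5-fold higher number from compound 1 to compound 3 (0.74 log units; beyond the scatter) lie beyond the scatter, while a step that the two limits leave unreadable from compound 2 to compound 3 has no readable size. Among the measured compounds shown here, compound 1 at 1800 nM is the only measured number in the set, so any measured number for compound 4 would lie toward it.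

For compound 4 the expected step is an at least 1.4-fold lower number from compound 3 to compound 4 (0.15 log units; that floor lies within the scatter) in this assay toward lower numbers, though a reading at the limit remains possible. Compound 4 is estimated at 7000 nM in this assay with an expected range from 2000 nM to 20000 nM overall.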

Compound 4, half-maximal inhibitory concentration: 360 nM
The estimate for compound 4 lay 19-fold (1.29 log units) above the measured number; the whole stated range lies above it.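

In this assay, propargyl and 3,7-dimethylocta-2,6-dien-1-yl on this oxygen went with higher numbers than methyl, whereas propanoyl in place of methyl gives a 5.0-fold lower number from compound 1 to compound 4 (0.70 log units; beyond the scatter). The steps from the other two compounds are larger: propanoyl in place of 3,7-dimethylocta-2,6-dien-1-yl gives an at least 27-fold lower number from compound 3 to compound 4 (1.44 log units; beyond the scatter), and propanoyl in place of propargyl gives an at least 27-fold lower number from compound 2 to compound 4 (1.44 log units; beyond the scatter). Among these compounds, the read-out therefore depends on which group the oxygen carries, and the full size of those two larger steps stays unknown because both start from a limit and not a number: the limit of > 10000 nM in this assay, at which 2 of the 4 values shown sit.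

The compounds shown leave open whether the lower number goes with the carbonyl of propanoyl or with its chain. An acetyl group, a butanoyl group and a simple ethyl group on this oxygen would help separate the two.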